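The compounds below may be only part of what the source reports. "The series", "measured", "known", "first", "only" and "open" are said of these compounds alone.

Measured in an ADME assay on Huh-7 cells (Homo sapiens) for cytotoxicity, read by MTT assay, with a stated time of 96 h; on this read-out lower numbers stand for higher toxicity in this test and higher numbers for lower toxicity in this test:
- compound 1 `COc1cc(NCc2ccc(C)o2)ccc1-c1cnco1`: 63400 nM
- compound 2 `COc1cc(NCc2ccc(Br)s2)ccc1-c1cnco1`: 39400 nM

Only these two numbers exist so far, and compound 2 stands level with compound 1 within the scatter. Compound 3 `CCc1ccc(CNc2ccc(-c3cnco3)c(OC)c2)s1` keeps the thiophene of compound 2 and carries ethyl in place of bromo on an aromatic carbon. The same difference, cut one bond further out, reads 5-bromothiophen-2-yl to 5-ethylthiophen-2-yl.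

Going by the values given here, no measured pair isolates this exchange. Among the compounds with values here, the one measured step that bears on it is a 1.6-fold lower number from compound 1 to compound 2 (0.21 log units; within the scatter), which replaced 5-methylfuran-2-yl with 5-bromothiophen-2-yl, so it altered both the ring and its substituent. That step gives only indirect guidance from a single pair, and it offers no reason to expect a shift beyond the scatter in this assay. The expected change is a 1.1-fold higher number from compound 2 to compound 3 (0.06 log units; within the scatter), an estimate that stays within the scatter. For compound 3 the estimated value is 45000 nM, with an expected range from 20000 nM to 90000 nM.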

Compound 3, half-maximal cytotoxic concentration: 39100 nM
Compound 3: middle estimate off by 1.2-fold (0.06 log units), on the high side, within the range that was stated.
By their numbers in this assay, from the lowest: compounds 3, 2 and 1 (each within the scatter of the next).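

The pair now isolates one exchange on the aromatic carbon next to the ring sulfur: in this assay, ethyl in place of bromo gives a 1.0-fold lower number from compound 2 to compound 3 (0.00 log units; within the scatter), so at this position on the thiophene these two groups stand level. The earlier step altered ring and substituent together and could not give this reading. The wider comparison, 5-ethylthiophen-2-yl in place of 5-methylfuran-2-yl, gives a 1.6-fold lower number from compound 1 to compound 3 (0.21 log units; within the scatter), which also lies within the scatter, so across compound 1, compound 2 and compound 3 none of these exchanges separates one compound from another in this assay. No measured data at hand account for these readings.

On these data alone, it remains open whether this position stays as flat with groups of a different kind, such as an aminomethyl group, a carboxylic acid or a longer chain such as hexyl, all of which would test it further than bromo and ethyl do. The furan and the thiophene also remain unseparated, since no pair among these compounds carries the same substituent on both rings.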